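Replacing the azetidin-1-yl group: a plasma binding estimate

The source may hold more compounds than are shown below. What is called first, only, known or untested is meant among the compounds shown, and "the series" means these compounds.

In an ADME assay on a cell-free system (plasma, Homo sapiens) for protein binding, compound 2 (`CNc1nccc(N2CC[C@H](NC(=O)Nc3ccc(CN4CCC4)c(C(F)(F)F)c3)C2)n1`) reads (86.3%). That leaves it the largest unbound share of three compounds, ahead of compound 1 (`CNc1nccc(N2CC[C@H](NC(=O)Nc3ccc(CN(C)C)c(C(F)(F)F)c3)C2)n1`; 94.3%) and compound 3 (`O=C(Nc1ccc(Cl)c(C(F)(F)F)c1)N[C@H]1CCN(c2ccncn2)C1`; 99.3%). Compound 4 (`CCN1CCN(Cc2ccc(NC(=O)N[C@H]3CCN(c4ccnc(NC)n4)C3)cc2C(F)(F)F)CC1`) puts 4-ethylpiperazin-1-yl in place of azetidin-1-yl on a saturated chain carbon bound to an aromatic carbon. Among the compounds with values here, only one measured step touches this place (a 2.4-fold higher unbound fraction from compound 1 to compound 2 (0.38 log units; beyond the scatter)), and it is modest. A step of similar size is therefore a fair guess. Since compound 2 sits at the free end of the three values, more binding seems the likelier direction, though the data cannot settle this. The expected change is a 1.7-fold lower unbound fraction from compound 2 to compound 4 (0.23 log units; within the scatter) as an estimate. Compound 4 is expected at 92% (estimated range 82% to 97%).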

Compound 4, plasma protein binding: 75.2%
The estimate for compound 4 lay 3.1-fold (0.49 log units) (unbound fraction) below the measured number; measured number outside the range, below it.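

Swapping azetidin-1-yl for the larger 4-ethylpiperazin-1-yl, on a saturated chain carbon bound to an aromatic carbon, gives a 1.8-fold higher unbound fraction from compound 2 to compound 4 (0.26 log units; within the scatter) in this assay, so this position accepts a much bigger ring without a clear shift. Measured against dimethylamino, the same group gives a 4.4-fold higher unbound fraction from compound 1 to compound 4 (0.64 log units; beyond the scatter), so among these three compounds a larger group does not go with a lower unbound fraction. No measurement here explains this result. As far as these compounds go, it remains open whether the ethyl group or the second ring nitrogen matters more. Piperidin-1-yl or morpholin-4-yl in this place would help separate the two.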